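A few compounds are considered here, and "the series" means these few. Any claim that something is new, unique, unknown or untested is made for them only; others in the source may bear on it.

Measured compounds:
compound 1, `CCCCOC(=O)c1ccc(COC(COCc2ccc(OC)cc2)Cn2ccnc2)cc1`: 200 nM
compound 2, `COc1ccc(COCC(Cn2ccnc2)OCc2ccc(C(=O)O)cc2)cc1`: 6700 nM

In a functional assay for inhibition of Thromboxane-A synthase (Homo sapiens) (on this read-out higher numbers stand for weaker inhibition and lower numbers for stronger inhibition), compound 2 holds the higher of the two numbers. Among the compounds with values here, its only neighbour is compound 1, and the single measured step, a 34-fold higher number from compound 1 to compound 2 (1.53 log units; beyond the scatter), is what separates them: the butyl ester of compound 1 gives way to the free acid of compound 2, and the number rises sharply.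

Compound 3, `COc1ccc(COCC(Cn2ccnc2)OCc2ccc(S(C)(=O)=O)cc2)cc1`, changes the same part of the molecule once more. The difference is methylsulfonyl in place of carboxy on an aromatic carbon; carried one bond out, it reads 4-carboxyphenyl to 4-(methylsulfonyl)phenyl. Within the data shown here, the only step that bears on it is the one from compound 1 to compound 2, which touched exactly this group and was large. Nothing measured shows what a methylsulfonyl group does here, so the direction can only be inferred loosely: the carboxy group that leaves is the one present in the weakest measured compound, and its removal is expected to lower the number, though by an uncertain amount. Compound 3 is therefore estimated at 1500 nM, within 300 nM to 8000 nM, an expected step of a 4.5-fold lower number from compound 2 to compound 3 (0.65 log units; beyond the scatter) from compound 2.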

Compound 3, half-maximal inhibitory concentration: 24900 nM
Compound 3: the middle estimate sits 17-fold (1.22 log units) below what was measured; measured number above the stated range.
By their numbers in this assay, from the lowest: compound 1; then compound 2; then compound 3.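

In this assay, methylsulfonyl in place of carboxy on the aromatic carbon does not bring the number back down but moves it further the same way, a 3.7-fold higher number from compound 2 to compound 3 (0.57 log units; beyond the scatter), so losing the carboxy group does not by itself restore inhibition at this position. Against the butoxycarbonyl group the change is larger still, a 120-fold higher number from compound 1 to compound 3 (2.10 log units; beyond the scatter), which leaves compound 1 as the strongest inhibitor of the three, with both groups that replace butoxycarbonyl at this position giving clearly higher numbers. No supporting measurement is available to explain this order among the three groups.

On these data alone, it remains open whether the low number of compound 1 belongs to the butyl chain or to the ester as such, and a methyl ester, a primary amide or a butyl ketone at the same place would separate those two readings. As far as these compounds go, it is also open whether a plain hydrogen or a nitrile there would sit nearer to compound 1 or to compound 3, and whether the same order would hold on a core carrying something other than the methoxy group.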